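Propylamino in place of bromo on compound 1

The compounds below may be only part of what the source reports. "The series", "measured", "known", "first", "only" and "open" are said of these compounds alone.

Compound 1 `C=CCOc1ccc(C(=O)Nc2cccc(Br)n2)cc1` gives 65500 nM in an in vitro assay on HEK-tsA201 cells for antagonist activity at Neuronal acetylcholine receptor; alpha3/beta4 (Homo sapiens), read by fluorescence and calcium flux; a higher number here means a weaker inhibitor, a lower number a stronger inhibitor. Of the three measured compounds only compound 1 gives a plain number. Compound 2 `CCCOc1ccc(C(=O)Nc2cccc(Br)n2)cc1` stops at the limit > 100000 nM in this assay. Compound 3 `CCCCCCNc1cccc(NC(=O)c2ccc(OCCC)cc2)n1` likewise stops at the limit > 100000 nM in this assay. The step of an at least 1.5-fold higher number from compound 1 to compound 2 (0.18 log units; that floor lies within the scatter) concerns the chain on the oxygen and changes little. The step that the two limits leave unreadable from compound 2 to compound 3 does concern an amino group replacing bromo, but cannot be sized because of the limit of > 100000 nM in this assay, at which 2 of the 3 values shown sit. Compound 4 `C=CCOc1ccc(C(=O)Nc2cccc(NCCC)n2)cc1` differs from compound 1 by propylamino in place of bromo on an aromatic carbon. For the measured compounds named here, the one measured step bearing on this change is unreadable, and compound 1 already sits close to the limit of > 100000 nM in this assay, at which 2 of the 3 values shown sit. Compound 4 is therefore expected around 100000 nM, within 40000 nM to 250000 nM, meaning a step of a 1.5-fold higher number from compound 1 to compound 4 (0.18 log units; within the scatter) that may well appear only as a limit.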

Compound 4, half-maximal inhibitory concentration: 11700 nM
Compound 4: middle estimate off by 8.5-fold (0.93 log units), on the high side, outside the stated range (below it).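

In this assay, for the compounds shown here, propylamino in place of bromo, next to the ring nitrogen, gives a 5.6-fold lower number from compound 1 to compound 4 (0.75 log units; beyond the scatter), the first readable step at this position. Bromo is therefore not needed on this carbon for a measurable value on the core of compound 1. Compound 3 gives only a limit, > 100000 nM, and the step to it from compound 2 cannot be read.

Open, as far as these compounds go, is whether a shorter amine such as methylamino or a cyclic amine such as piperidine would move the number further at this carbon. Also open, from the compounds shown here alone, is whether propylamino gives a similar step on compound 2.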